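The source may report more compounds than this note shows. Statements on the series, on what has been measured and on what is new or still open speak of the compounds shown alone.

Among the compounds with values here, compound 3 `C[C@H]1CC(Cl)=C([Si](C)(C)C)[C@@H](C2CCCCC2)O1` holds the only number so far: in a functional assay on SW1573 cells (Homo sapiens) for antiproliferative activity (a lower number here means a stronger inhibitor of growth, a higher number a weaker inhibitor of growth), compound 3 gives 16000 nM. Compound 2 `CCC(C)[C@H]1O[C@@H](C)CC(Cl)=C1[Si](C)(C)C` sits at a limit of the assay, where compound 2 gives > 100000 nM. Compound 1 `CC(C)CC1C=C(Cl)CCO1` likewise sits at a limit, and compound 1 gives > 100000 nM. Within the data shown here, the single measured step is an at least 6.2-fold lower number from compound 2 to compound 3 (0.79 log units; beyond the scatter); two of the three values rest at the limit of > 100000 nM in this assay, at which 2 of the 3 values shown sit. Compound 4 `C[C@H]1CC(Cl)=C[C@@H](C2CCCCC2)O1` differs from compound 3 by a hydrogen atom in place of a group of 4 heavy atoms (3 carbon, 1 silicon; no ring), on a double-bonded ring carbon. Among the measured compounds shown here, no measured step concerns this change. Compound 4 is expected to be weaker than compound 3, a 5.0-fold higher number from compound 3 to compound 4 (0.70 log units; beyond the scatter), since compound 1, which also lacks this group, sits at the limit of > 100000 nM in this assay, at which 2 of the 3 values shown sit. The estimate for compound 4 in this assay is 80000 nM, between 16000 nM and 300000 nM, with a fair chance of only a limit.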

Compound 4, concentration for 50% growth inhibition: 12000 nM
Compound 4: the middle estimate sits 6.7-fold (0.82 log units) above what was measured; the measured number lies below the stated range.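

In this assay the step is a 1.3-fold lower number from compound 3 to compound 4 (0.12 log units; within the scatter), so on this double-bonded ring carbon, with cyclohexyl present, a hydrogen atom and the group of 4 heavy atoms (3 carbon, 1 silicon) read alike. That group is therefore not required for the growth inhibition seen with compound 3. Compound 3 and compound 4 both stand clear of the limit that holds the other values: the limit of > 100000 nM in this assay, at which 2 of the 4 values shown sit.

As far as these compounds go, it remains open whether a hydroxyl, an amine or a longer chain on this carbon would shift the number. Also open, from the compounds shown here alone, is whether the same exchange reads alike with sec-butyl in place of cyclohexyl.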